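This account rests on a few compounds, and the source may have more. Where it says the series, first, only, none or still open, it means among the compounds named here.

Compound 1, `COc1ccc(/C=C\c2cc(OC)c(OC)c(OC)c2)cc1OCc1ccc(CNC(C)(C)C(=O)O)cc1`: in a functional assay on MC-38 cells (Mus musculus) for antiproliferative activity, read by CCK-8 assay, with a stated time of 48 h (on this read-out higher numbers stand for weaker inhibition and lower numbers for stronger inhibition), compound 1 gives only a limit, > 10000 nM.
Compound 2, `COc1ccc(/C=C\c2cc(OC)c(OC)c(OC)c2)cc1OCc1ccc(CN2CCCC[C@@H]2C(=O)O)cc1`: in this assay compound 2 likewise gives only a limit, > 10000 nM.
Compound 3, `COc1ccc(/C=C\c2cc(OC)c(OC)c(OC)c2)cc1OCc1ccc(CNCCO)cc1`: in this assay compound 3 gives 1200 nM.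

Compound 1 thus sits at the top of the measured range, at the limit of > 10000 nM in this assay, at which 2 of the 3 values shown sit, with no number of its own. The unmeasured compound 4 is `COc1ccc(/C=C\c2cc(OC)c(OC)c(OC)c2)cc1OCc1ccc(CN2CC[C@H](O)C2)cc1`. It differs from compound 1 by 3-hydroxypyrrolidin-1-yl in place of (1-carboxy-1-methylethyl)amino on a saturated chain carbon bound to an aromatic carbon. The carboxylic acid of compound 1 leaves, as it does in compound 3, where the change was an at least 8.3-fold lower number from compound 1 to compound 3 (0.92 log units; beyond the scatter). The step that the two limits leave unreadable from compound 1 to compound 2 keeps the acid and offers no direction. Since compound 4 keeps a hydroxyl and an amine as compound 3 does, a step of similar size toward lower numbers is expected, an at least 10-fold lower number from compound 1 to compound 4 (1.00 log units; beyond the scatter). Compound 4 is therefore estimated at 1000 nM in this assay, with a likely range from 300 nM to 5000 nM.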

Compound 4, half-maximal inhibitory concentration: 7200 nM
For compound 4 the middle estimate is 7.2-fold (0.86 log units) below the measured one; measured number outside the range, above it.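

Dropping the carboxylic acid is not enough on its own. In this assay, 3-hydroxypyrrolidin-1-yl in place of (2-hydroxyethyl)amino gives a 6.0-fold higher number from compound 3 to compound 4 (0.78 log units; beyond the scatter), so a hydroxyl and an amine nitrogen kept on the same saturated chain carbon do not by themselves hold the activity of compound 3, and tying them into a five-membered ring goes with a clear loss. The steps from the two acids are only floors that lie within the scatter, an at least 1.3-fold lower number from compound 1 to compound 4 (0.14 log units; that floor lies within the scatter) and an at least 1.3-fold lower number from compound 2 to compound 4 (0.14 log units; that floor lies within the scatter), so compound 4 cannot be ranked against compound 1 or compound 2, which give no number of their own: the limit of > 10000 nM in this assay, at which 2 of the 4 values shown sit.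

Going by these compounds, whether the ring or the placement of the hydroxyl goes with this loss stays open. A plain pyrrolidin-1-yl, a (3-hydroxypropyl)amino group or the opposite stereoisomer of compound 4 on the same carbon could separate these.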